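Trading Methoxy for Methyl on a Nitro Compound

This account rests on a few compounds, and the source may have more. Where it says the series, first, only, none or still open, it means among the compounds named here.

In a functional assay on QG-56 cells (Homo sapiens) for antiproliferative activity (on this read-out higher numbers stand for weaker inhibition and lower numbers for stronger inhibition), compound 1 `COc1cccc(-c2cc([N+](=O)[O-])cc3cc(C(O)(c4ccc(C#N)cc4)c4cncn4C)oc23)c1` gives 38.8 nM, the lower of the two numbers available. Compound 2 `COc1cccc(-c2cc(CN(C)C)cc3cc(C(O)(c4ccc(C#N)cc4)c4cncn4C)oc23)c1` gives 142 nM, and compound 3 `COc1cccc(-c2cc(C(=O)NN3CCOCC3)cc3cc(C(O)(c4ccc(C#N)cc4)c4cncn4C)oc23)c1` has no number: "not determined" (no result reported). Compound 4 `Cc1cccc(-c2cc([N+](=O)[O-])cc3cc(C(O)(c4ccc(C#N)cc4)c4cncn4C)oc23)c1` keeps the core of compound 1 but has methyl in place of methoxy on an aromatic carbon, turning 3-methoxyphenyl into 3-methylphenyl. Going by the values given here, the only measured step, a 3.7-fold higher number from compound 1 to compound 2 (0.56 log units; beyond the scatter), swaps nitro for (dimethylamino)methyl and leaves the methoxy untouched, so it offers no direct guide to this change. No step beyond the scatter is therefore expected in this assay. The estimated step is a 1.0-fold higher number from compound 1 to compound 4 (0.01 log units; within the scatter). Compound 4 is expected at 40 nM, within a range of 15 nM to 110 nM.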

Compound 4, half-maximal inhibitory concentration: 23.2 nM
Compound 4: middle estimate off by 1.7-fold (0.24 log units), on the high side, and the stated range covers the measured number.
By their numbers in this assay, from the lowest: compounds 4 and 1 (each within the scatter of the next); then compound 2.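

Turning 3-methoxyphenyl into 3-methylphenyl while keeping the nitro group gives a 1.7-fold lower number from compound 1 to compound 4 (0.22 log units; within the scatter) in this assay. On this nitro compound, then, the methoxy oxygen and its one hydrogen-bond acceptor are not needed to hold the number at this level. Nothing available explains this result. The compounds shown leave open whether an amine, a hydroxyl or a carboxylic acid on this same aromatic carbon would also hold the number. They also leave open whether methyl for methoxy would behave alike in compound 2, which carries (dimethylamino)methyl instead of nitro.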